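The source may report more compounds than this note shows. Statements on the series, on what has been measured and on what is new or still open speak of the compounds shown alone.

Measured in a functional assay on NALM-6 cells (Homo sapiens) for cytotoxicity, with a stated time of 72 h; a higher number here means that more compound is needed for the effect, a lower number that less compound is needed:

- compound 1 `C=C[C@@](C)(/C=C/c1ccc(O)c(CO)c1)CCC=C(C)C` gives 16400 nM
- compound 2 `C=C[C@@](C)(/C=C/c1ccc(O)c(/C=C/C#N)c1)CCC=C(C)C` gives > 43400 nM (a limit, not a number)
- compound 3 `COc1ccc(/C=C/[C@@](C)(/C=C/c2ccc(O)c(/C=C/C#N)c2)CCC=C(C)C)cc1` gives 16500 nM

Compound 3 at 16500 nM and compound 1 at 16400 nM lie within the usual scatter of each other. Compound 4 `COc1ccc(/C=C/[C@@](C)(/C=C/c2ccc(O)c(/C=C/C(=O)c3ccccc3)c2)CCC=C(C)C)cc1` carries benzoyl in place of cyano on a double-bonded chain carbon bound to a double-bonded chain carbon, so 2-cyanoethenyl becomes 2-benzoylethenyl.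

Among the measured compounds shown here, two measured steps bear on this, though only loosely. The step of an at least 2.6-fold higher number from compound 1 to compound 2 (0.42 log units; beyond the scatter) brought in the 2-cyanoethenyl group that is now altered. The step of an at least 2.6-fold lower number from compound 2 to compound 3 (0.42 log units; beyond the scatter) concerns a different part of the molecule. Both rest on the limit of > 43400 nM in this assay, at which 1 of the 3 values shown sits, and so give only a minimum size. For the measured compounds named here, no measured step swaps cyano for benzoyl, so no clear shift in either direction is expected from compound 3 at 16500 nM in this assay.

The expected change is a 1.3-fold lower number from compound 3 to compound 4 (0.10 log units; within the scatter) and would stay modest. For compound 4 the estimate is 13000 nM with an expected range of 4000 nM to 40000 nM.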

Compound 4, half-maximal effective concentration: > 43400 nM
Compound 4: no number, only a limit; the forecaster's own chance of this, stated with the estimate: 15%; middle value at least 3.3-fold (0.52 log units) away from the limit.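

Replacing cyano with benzoyl on a double-bonded chain carbon bound to a double-bonded chain carbon gives an at least 2.6-fold higher number from compound 3 to compound 4 (0.42 log units; beyond the scatter) in this assay, the first measured sign that the far end of this side group affects the read-out. Compound 4 gives > 43400 nM, which is a limit and not a number. The step is therefore only a minimum size, and the true value of compound 4 cannot be placed: the limit of > 43400 nM in this assay, at which 2 of the 4 values shown sit.

The compounds shown do not tell whether the rise comes with the added aromatic ring, the carbonyl or the loss of cyano itself. A methyl ester or a primary amide on the same carbon could help separate these, showing whether the read-out stays with compound 3 at 16500 nM or moves away from that value.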